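Moving the chlorine on the benzyl ether of compound 2

The source may hold more compounds than are shown below. What is called first, only, known or untested is meant among the compounds shown, and "the series" means these compounds.

Compound 1 `O=C(NC1CCCNC1)c1ccccc1OCc1ccccc1Cl`: > 100000 nM in an assay on lysate for inhibition of phosphatidylcholine:ceramide cholinephosphotransferase 2 (Homo sapiens), read by HPLC, with stated times of 30 min and 2 h; on this read-out higher numbers stand for weaker inhibition and lower numbers for stronger inhibition; this is a limit of the assay, not a number.
Compound 2 `O=C(Nc1cccnc1)c1ccccc1OCc1ccccc1Cl`: 1100 nM in this assay.
Compound 3 `O=C(Nc1cccnc1)c1ccccc1OCc1ccccc1C(F)(F)F`: 2100 nM in this assay.

Of the two numbers shown, compound 2 has the lowest, and compound 3 is nearest: a 1.9-fold higher number from compound 2 to compound 3 (0.28 log units; within the scatter). Within the data shown here, the only large measured step is an at least 90-fold lower number from compound 1 to compound 2 (1.95 log units; beyond the scatter), which starts from the limit of > 100000 nM in this assay, at which 1 of the 3 values shown sits.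

Compound 4 `O=C(Nc1cccnc1)c1ccccc1OCc1cccc(Cl)c1` differs from compound 2 by 3-chlorophenyl in place of 2-chlorophenyl on a saturated chain carbon bound to an oxygen on an aromatic ring. Among the measured compounds shown here, no measured step tests this change; the closest is the substituent swap on the same ring, a 1.9-fold higher number from compound 2 to compound 3 (0.28 log units; within the scatter). The expected step is therefore a 1.5-fold higher number from compound 2 to compound 4 (0.16 log units; within the scatter), within the scatter. Compound 4 is estimated at 1600 nM, between 500 nM and 6000 nM.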

Compound 4, half-maximal inhibitory concentration: 1400 nM
Compound 4: middle estimate off by 1.1-fold (0.06 log units), on the high side; the range from low to high includes it.
By their numbers in this assay, from the lowest: compounds 2, 4 and 3 (each within the scatter of the next). At a limit, above all of these: compound 1.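

The earlier compounds shown here changed which group sat on this ring, whereas this pair changes only where the chlorine sits: 3-chlorophenyl in place of 2-chlorophenyl gives a 1.3-fold higher number from compound 2 to compound 4 (0.10 log units; within the scatter) in this assay. So the two placements of the chlorine are not told apart by these numbers. Nothing measured here gives a reason for this result. Still open, from the compounds shown here alone, is whether a different kind of group on this ring, such as an amine or a carboxylic acid, would shift the number beyond the scatter.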